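Hydroxy for acetamido at the assay limit

This account rests on a few compounds, and the source may have more. Where it says the series, first, only, none or still open, it means among the compounds named here.

In a functional assay on PC-3 cells (Homo sapiens) for cytotoxicity (on this read-out lower numbers stand for stronger inhibition and higher numbers for weaker inhibition), compound 1 (`Nc1[nH]nc2nncc(-c3ccccc3)c12`) has the entry "not determined" (no result reported). Compound 2 (`CC(=O)Nc1[nH]nc2nnc(-c3ccccc3)c(-c3ccccc3)c12`) gives > 100000 nM, which is a limit of the assay and not a number. Compound 3 (`COc1ccc(-c2[nH]nc3nnc(N)c-3c2-c2ccc(OC)cc2)cc1`) gives > 100000 nM, also a limit. For the measured compounds named here, compound 2 therefore stands at the limit of > 100000 nM in this assay, at which 2 of the 3 values shown sit, and the series offers no measured single-place step for comparison. Compound 4 (`Oc1[nH]nc2nnc(-c3ccccc3)c(-c3ccccc3)c12`) carries hydroxy in place of acetamido on an aromatic carbon. In this assay, no change beyond the scatter is expected in either direction, and the expected step is a number no higher from compound 2 to compound 4 (the limit leaves the size open). For compound 4 the estimate is 100000 nM, with an expected range of 30000 nM to 300000 nM.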

Compound 4, half-maximal inhibitory concentration: > 100000 nM
Compound 4 was reported as a limit; the forecaster's own chance of this, stated with the estimate: 70%; the middle value lies on the limit itself.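

In this assay no step from compound 2 to compound 4 can be read, as both entries are limits of the assay and not numbers: the limit of > 100000 nM in this assay, at which 3 of the 4 values shown sit.

Whether hydroxy in place of acetamido changes the read-out at all stays open, with no single number among the compounds shown.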